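A few compounds are considered here, and "the series" means these few. Any claim that something is new, unique, unknown or untested is made for them only; others in the source may bear on it.

Among the compounds with values here, in a functional assay on MCF7 cells (Homo sapiens) for antiproliferative activity, read by sulforhodamine B assay, with a stated time of 48 h (on this read-out higher numbers stand for weaker inhibition and lower numbers for stronger inhibition), two compounds built on the same core have numbers so far. Compound 1 `COc1ccc(OC)c(/C=C/C(=O)C(=Cc2ccc(OC)c(OC)c2)C(=O)/C=C/c2cc(OC)ccc2OC)c1` gives 850 nM, and compound 2 `COc1ccc(OC)c(/C=C/C(=O)C(=Cc2ccc(O)c(F)c2)C(=O)/C=C/c2cc(OC)ccc2OC)c1` gives 460 nM. These two values cannot be told apart: the step of a 1.8-fold lower number from compound 1 to compound 2 (0.27 log units; within the scatter) lies within the scatter, so compound 2 stands level with compound 1.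

Compound 3 `COc1ccc(OC)c(/C=C/C(=O)C(=Cc2cc(OC)c(O)c(OC)c2)C(=O)/C=C/c2cc(OC)ccc2OC)c1` is changed at the same place, on a double-bonded chain carbon bound to a double-bonded chain carbon: 4-hydroxy-3,5-dimethoxyphenyl in place of 3-fluoro-4-hydroxyphenyl on a double-bonded chain carbon bound to a double-bonded chain carbon. The 4-hydroxy-3,5-dimethoxyphenyl group keeps a hydroxy group, as in compound 2, and carries methoxy groups, as in compound 1.

Within the data shown here, only one measured step bears on this place, and it is a thin basis for a forecast. Still, swapping 3,4-dimethoxyphenyl for 3-fluoro-4-hydroxyphenyl there gave only a 1.8-fold lower number from compound 1 to compound 2 (0.27 log units; within the scatter), so no shift beyond the scatter is expected in this assay. The estimated step is a 1.2-fold higher number from compound 2 to compound 3 (0.08 log units; within the scatter), with no firm direction implied. For compound 3 the expected value is 550 nM, with an estimated range from 200 nM to 1500 nM.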

Compound 3, half-maximal inhibitory concentration: 430 nM
Estimate against measurement, compound 3: 1.3-fold (0.11 log units) above, within the range that was stated.
By their numbers in this assay, from the lowest: compounds 3, 2 and 1 (each within the scatter of the next).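

In this assay, the step to the 4-hydroxy-3,5-dimethoxyphenyl group adds heavy atoms and hydrogen-bond acceptors, with 11 heavy atoms and 3 acceptors replacing 8 and 1, yet it gives a 1.1-fold lower number from compound 2 to compound 3 (0.03 log units; within the scatter). The comparison with the 3,4-dimethoxyphenyl group gives a 2.0-fold lower number from compound 1 to compound 3 (0.30 log units; within the scatter), so all three compounds now stand level, and this place has accepted three differently decorated phenyl rings, with or without a hydroxy group and with fluorine or methoxy groups, without a change that can be told from the scatter. Nothing available explains why these three groups read alike.

As far as these compounds go, the three groups are all substituted phenyl rings, so it remains open whether a phenyl ring carrying an amine or a carboxylic acid, or a longer chain at this place, would move the number beyond the scatter. The rest of the shared core is also the same in compounds 1, 2 and 3, so these results say nothing about changes made elsewhere on it.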